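The compounds below may be only part of what the source reports. "The series", "measured", "known", "first", "only" and "open" are said of these compounds alone.

Compound 1 `C[C@@H](Cn1ccc(-c2ccc(C#N)c(Cl)c2)n1)NC(=O)c1ccccc1F` gives 1810 nM in a functional assay on LNCaP cells (Homo sapiens) for antiproliferative activity, read by CCK-8 assay, with a stated time of 6 days; on this read-out higher numbers stand for weaker inhibition and lower numbers for stronger inhibition. Compound 2 `C[C@@H](Cn1ccc(-c2ccc(C#N)c(Cl)c2)n1)NC(=O)C1CC(=O)C1` gives 3040 nM. Compound 3 `C[C@@H](Cn1ccc(-c2ccc(C#N)c(Cl)c2)n1)Nc1ccccc1` gives 710 nM.

On these numbers compound 3 stands lowest of the three, with the steps of a 2.5-fold lower number from compound 1 to compound 3 (0.41 log units; beyond the scatter) and a 4.3-fold lower number from compound 2 to compound 3 (0.63 log units; beyond the scatter) both beyond the scatter. Compound 4 `C[C@@H](Cn1ccc(-c2ccc(C#N)c(Cl)c2)n1)Nc1ccccn1` differs from compound 3 by pyridin-2-yl in place of phenyl on an amine nitrogen. Going by the values given here, the two measured steps replace an amide-bearing group with a plain phenyl on that nitrogen; neither swaps one aromatic ring for another on an amine, so no measured step bears directly on the change to compound 4. Compound 3 is therefore taken as the anchor, and compound 4 is expected to show a 1.3-fold higher number from compound 3 to compound 4 (0.10 log units; within the scatter), not beyond the scatter. Compound 4 is estimated at 900 nM, within 350 nM to 2500 nM.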

Compound 4, half-maximal inhibitory concentration: 1110 nM
Estimate against measurement, compound 4: 1.2-fold (0.09 log units) below; low and high end bracket the measured number.
By their numbers in this assay, from the lowest: compounds 3, 4, 1 and 2 (each within the scatter of the next, the first and the last beyond it).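

In this assay, the swap of one aromatic ring for another on the amine nitrogen gives a 1.6-fold higher number from compound 3 to compound 4 (0.19 log units; within the scatter), so adding a ring nitrogen and a hydrogen-bond acceptor to this group leaves the number within the scatter. The pyridin-2-yl group still gives a 2.7-fold lower number from compound 2 to compound 4 (0.44 log units; beyond the scatter), whereas a 1.6-fold lower number from compound 1 to compound 4 (0.21 log units; within the scatter) stays within the scatter, unlike the phenyl step from that same amide. Nothing available explains these numbers. The compounds shown leave open whether pyridin-3-yl, pyridin-4-yl or pyrimidin-2-yl on this amine nitrogen would give a similar number.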